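Aryl swap on the saturated ring carbon of the core

The compounds below may be only part of what the source reports. "The series", "measured", "known", "first", "only" and "open" are said of these compounds alone.

Among the compounds with values here, compound 1 `Fc1ccc(C2CC(c3ccc4c(c3)OCCO4)=NN2c2ccccc2)cc1` gives 6050 nM in a functional assay on WM 266-4 cells (Homo sapiens) for antiproliferative activity, read by MTT assay, with a stated time of 24 h (on this read-out higher numbers stand for weaker inhibition of growth and lower numbers for stronger inhibition of growth), and is the sole number in the set. Compound 2 `COc1ccc(C2CC(c3ccc4c(c3)OCCO4)=NN2c2ccccc2)cc1` reaches only a limit of this assay, > 100000 nM. Within the data shown here, the single measured step, an at least 16-fold higher number from compound 1 to compound 2 (1.21 log units; beyond the scatter), rests on (the limit of > 100000 nM in this assay, at which 1 of the 2 values shown sits). Compound 3 `c1ccc(N2N=C(c3ccc4c(c3)OCCO4)CC2c2cccc3ccccc23)cc1` differs from compound 1 by naphthalen-1-yl in place of 4-fluorophenyl on a saturated ring carbon. That measured step changes a substituent on the ring that leaves, not the ring itself, so it bears only loosely here; a step of a 1.3-fold higher number from compound 1 to compound 3 (0.12 log units; within the scatter) within the scatter is expected in this assay. Compound 3 is estimated at 8000 nM, between 2000 nM and 60000 nM.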

Compound 3, concentration for 50% growth inhibition: > 100000 nM
Compound 3: a limit, no number (the forecaster's own chance of this, stated with the estimate: 25%); at least 12-fold (1.09 log units) between middle value and limit.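

Replacing the whole ring, and not only its substituent, also weakens growth inhibition in this assay: naphthalen-1-yl in place of 4-fluorophenyl gives an at least 16-fold higher number from compound 1 to compound 3 (1.21 log units; beyond the scatter). Among the three compounds, only compound 1, with 4-fluorophenyl on the saturated ring carbon, keeps a number. The step between compound 2 and compound 3 cannot be read, and both stand at a limit of the assay: the limit of > 100000 nM in this assay, at which 2 of the 3 values shown sit.

Going by these compounds, it remains open whether unsubstituted phenyl, 4-chlorophenyl or an aryl group carrying an amine at this carbon would keep a number. On these data alone, how far compound 2 and compound 3 lie past the limit also remains open.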